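This account rests on a few compounds, and the source may have more. Where it says the series, first, only, none or still open, it means among the compounds named here.

Measured so far in an assay on isolated protein for inhibition of matrix metalloproteinase-9 (Homo sapiens); a lower number here means a stronger inhibitor, a higher number a weaker inhibitor:
compound 1 `COc1ccc(COC(=O)c2cccc(=O)[nH]2)cc1` gives 100000 nM
compound 2 `O=C(Oc1cccc2ccccc12)c1cccc(=O)[nH]1` gives 109000 nM
compound 3 `O=C(OCc1cccc(-c2ccccc2)c1)c1cccc(S)n1` gives 50000 nM

All three numbers sit at the weak end of the read-out. Compound 1 stands second highest of the three; compound 2 is nearest and compound 3 furthest, and both gaps fall within the usual scatter, so no order among the three is established. Compound 4 `O=C(OCc1ccc(Cl)cc1)c1cccc(=O)[nH]1` differs from compound 1 by chloro in place of methoxy on an aromatic carbon. For the measured compounds named here, no measured pair shows this change, and the three numbers give no ground for a shift beyond the scatter in either direction. The expected step is a 1.1-fold lower number from compound 1 to compound 4 (0.05 log units; within the scatter), nothing beyond the scatter. Compound 4 is expected at 90000 nM in this assay, with a range from 40000 nM to 200000 nM.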

Compound 4, half-maximal inhibitory concentration: 68000 nM
Compound 4: middle estimate off by 1.3-fold (0.12 log units), on the high side, and the stated range covers the measured number.
By their numbers in this assay, from the lowest: compounds 3, 4, 1 and 2 (each within the scatter of the next, the first and the last beyond it).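

In this assay, chloro in place of methoxy on this aromatic carbon, para to a large group, gives a 1.5-fold lower number from compound 1 to compound 4 (0.17 log units; within the scatter), so this single change leaves the number at the weak end of the read-out. With one heavy atom fewer and one hydrogen-bond acceptor fewer, the group at this place still shows no shift beyond the scatter. Nothing measured on these compounds explains this step.

From the compounds shown here alone, whether an amine, a carboxylic acid or a longer chain at this carbon would shift the number beyond the scatter stays open. So does whether this step would carry over to another core.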